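Methoxy to trifluoromethoxy on the aryl of a shared core

A few compounds are considered here, and "the series" means these few. Any claim that something is new, unique, unknown or untested is made for them only; others in the source may bear on it.

Compound 2 `COc1ccc(C2=Nn3c(nnc3C(C)c3ccc4cc(OC)ccc4c3)SC2)cc1`: 8500 nM
Compound 1 `COc1ccc2cc(C(C)c3nnc4n3N=C(c3ccc(Cl)cc3Cl)CS4)ccc2c1`: 10700 nM

Of the compounds shown here, two have been measured in a functional assay on Huh-7 cells (Homo sapiens) for inhibition, read by sulforhodamine B assay, with a stated time of 72 h; a higher number here means a weaker inhibitor, a lower number a stronger inhibitor. Compound 2 gives 8500 nM, and compound 1 gives 10700 nM. Going by the values given here, compound 2 has the lowest of these two numbers, but its only neighbour is compound 1 at a 1.3-fold lower number from compound 1 to compound 2 (0.10 log units; within the scatter), so the two cannot be told apart.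

Compound 3 `COc1ccc2cc(C(C)c3nnc4n3N=C(c3ccc(OC(F)(F)F)cc3)CS4)ccc2c1` is not yet measured. It differs from compound 2 at one place: trifluoromethyl in place of methyl on an oxygen on an aromatic ring.

Among the compounds with values here, the only step that bears on this change is the one at the same aryl group, a 1.3-fold lower number from compound 1 to compound 2 (0.10 log units; within the scatter), where a much larger swap of the aryl left the number within the scatter. A smaller swap at the same place is therefore expected to do little: compound 3 is expected to give 9000 nM (range 4000 nM to 20000 nM), a step of a 1.1-fold higher number from compound 2 to compound 3 (0.02 log units; within the scatter), no more than the scatter.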

Compound 3, half-maximal inhibitory concentration: 16000 nM
Compound 3: middle estimate off by 1.8-fold (0.25 log units), on the low side, within the range that was stated.
By their numbers in this assay, from the lowest: compounds 2, 1 and 3 (each within the scatter of the next).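

In this assay, trifluoromethoxy in place of methoxy on the aryl of the shared core gives a 1.9-fold higher number from compound 2 to compound 3 (0.27 log units; within the scatter) and so stays within the scatter, even with fluorine on the group. Compared with the 2,4-dichlorophenyl group, the 4-(trifluoromethoxy)phenyl group gives a 1.5-fold higher number from compound 1 to compound 3 (0.17 log units; within the scatter) and is also within the scatter, so none of the three aryl groups shown at this place can yet be told apart from the others. No measurement here explains why these numbers lie so close together. From the compounds shown here alone, it remains open whether an amine or a carboxylic acid on this aryl would give a step beyond the scatter. Also open, going by these compounds, is whether any group at this place can bring the number well below those of these three compounds.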